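Amino in Place of Methoxy on a Halogenated Hydrazide Core

A few compounds are considered here, and "the series" means these few. Any claim that something is new, unique, unknown or untested is made for them only; others in the source may bear on it.

The series rests on three measured compounds that share a benzoyl hydrazide core carrying a dihalogenated aryl ring. Compound 1, `COc1ccc(C(=O)NNc2c(Br)cccc2Br)cc1`, is the parent of the step that follows. In a toxicity assay on MDCK cells (Canis lupus familiaris) for cytotoxicity, read by CCK-8 assay, with a stated time of 48 h (a lower number here means that less compound is tolerated, a higher number that more compound is tolerated), compound 1 reaches only the limit of > 100000 nM, so no number is known for it. Compound 2, `CCOc1ccc(C(=O)N(C)Nc2c(Cl)cccc2Cl)cc1`, likewise gives a limit of > 100000 nM in this assay. Compound 3, `CCCc1ccc(C(=O)NNc2c(Cl)cccc2Cl)cc1`, also stops at the limit of > 100000 nM in this assay. Within what has been measured, compound 1 therefore stands nowhere in particular: the limit of > 100000 nM in this assay, at which 3 of the 3 values shown sit, and no measured step separates any two of these compounds.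

The unmeasured compound 4, `Nc1ccc(C(=O)NNc2c(Br)cccc2Br)cc1`, differs from compound 1 in one place: amino in place of methoxy on an aromatic carbon. Because every value shown sits at the limit (the limit of > 100000 nM in this assay, at which 3 of the 3 values shown sit), the step is expected to be none beyond the scatter, and the estimated change reads a step that the limit leaves unreadable from compound 1 to compound 4. On that basis compound 4 is expected to tolerate about 150000 nM in this assay, with an estimated range from 60000 nM to 400000 nM, and most likely to be reported again only as a limit rather than a number.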

Compound 4, half-maximal cytotoxic concentration: > 100000 nM
Compound 4: a limit, no number (the forecaster's own chance of this, stated with the estimate: 70%); the middle value is on the limit's open side.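

In this assay compound 4 gives > 100000 nM as a limit and not a number. No step from compound 1 to compound 4 can be read, because both compounds stop at a limit, as every compound shown does: the limit of > 100000 nM in this assay, at which 4 of the 4 values shown sit. The compounds shown leave open how far any of them lies past that limit, and whether amino and methoxy differ here at all.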